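From Naphthalen-1-yl to 2-Fluorophenyl at the Limit

The source may report more compounds than this note shows. Statements on the series, on what has been measured and on what is new or still open speak of the compounds shown alone.

Of the compounds shown here, three have been tested in an ADME assay on cells (Astrocyte, Homo sapiens) for cytotoxicity, read by WST assay, with a stated time of 72 h (on this read-out lower numbers stand for stronger inhibition and higher numbers for weaker inhibition), so far. Compound 1 (`O=C(Nc1ccccc1F)Nc1cc2ncncc2cc1OCc1ccccc1`) gives > 10000 nM as a limit, not a number. Compound 2 (`O=C(Nc1ccccc1F)Nc1cc2ncncc2cc1OCc1cccc(Cl)c1`) gives 8700 nM as a true measurement. Chloro in place of hydrogen on an aromatic carbon gives an at least 1.1-fold lower number from compound 1 to compound 2 (0.06 log units; that floor lies within the scatter) and is the only measured step. Compound 3 (`O=C(Nc1cc2ncncc2cc1OCc1cccc(F)c1)Nc1cccc2ccccc12`) gives > 10000 nM as a limit too. The main feature of the data is therefore the limit of > 10000 nM in this assay, at which 2 of the 3 values shown sit, and little else.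

Compound 4 (`O=C(Nc1ccccc1F)Nc1cc2ncncc2cc1OCc1cccc(F)c1`) has 2-fluorophenyl in place of naphthalen-1-yl on an amide-type nitrogen, with the count 2-fluorophenyl in place of naphthalen-1-yl on an amide-type nitrogen describing the exchange. Within the data shown here, no measured step makes this exchange, although compound 1 and compound 2 both carry 2-fluorophenyl. Compound 2 stands at 8700 nM, so no large step is expected. The expected step is a number no higher from compound 3 to compound 4 (the limit leaves the size open) and should not go clearly beyond the scatter. For compound 4 the estimate is 10000 nM with an expected range of 5000 nM to 20000 nM in this measurement.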

Compound 4, half-maximal inhibitory concentration: > 10000 nM
Compound 4 gave a limit, no number (the forecaster's own chance of this, stated with the estimate: 60%); the middle value sits exactly at the limit.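

With 2-fluorophenyl kept on the amide-type nitrogen, fluoro in place of chloro on an aromatic carbon gives an at least 1.1-fold higher number from compound 2 to compound 4 (0.06 log units; that floor lies within the scatter). The steps that link compound 4 to compound 3 and to compound 1 have limits at both ends and cannot be read, so the exchange of naphthalen-1-yl for 2-fluorophenyl has no readable size here. Among these compounds, compound 4 joins the compounds that give no true number, which leaves compound 2 as the only measured value in the set and makes one feature dominate the data: the limit of > 10000 nM in this assay, at which 3 of the 4 values shown sit.

Going by these compounds, how far compound 1, compound 3 and compound 4 lie past that limit remains open. Also open, on these data alone, is whether an amine or a carboxylic acid in place of 2-fluorophenyl on the amide-type nitrogen would give a true number in this assay.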